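Compound 3 against the limit of the series

The source may hold more compounds than are shown below. What is called first, only, known or untested is meant among the compounds shown, and "the series" means these compounds.

Of the compounds shown here, two have been read so far. In a functional assay on Jurkat cells (Homo sapiens) for cytotoxicity, with a stated time of 72 h (on this read-out higher numbers stand for an effect only at larger amounts of compound and lower numbers for an effect already at smaller amounts), compound 1 (`C=C[C@@](C)(/C=C/c1ccc(O)cc1)CC/C=C/C#N`) gives > 49000 nM as a limit of the assay, not a number. Compound 2 (`C=C[C@@](C)(/C=C/c1ccc(O)c(C=O)c1)CCC=C(C)C`) gives > 49000 nM as a limit too, so it holds no numerical position in this assay and offers only a bound. The whole data set amounts to one entry (the limit of > 49000 nM in this assay, at which 2 of the 2 values shown sit). For the measured compounds named here, no step between measured compounds is available to set a scale for a change.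

Compound 3 (`C=C[C@@](C)(/C=C/c1ccc(O)c(/C=C/C(=O)O)c1)CCC=C(C)C`) carries 2-carboxyethenyl in place of formyl on an aromatic carbon, ortho to a hydroxy group and meta to a large group (2-carboxyethenyl in place of formyl on an aromatic carbon).

In this assay the expected step (a number no higher from compound 2 to compound 3 (the limit leaves the size open)) is estimated to stay within the scatter, with no direction favoured. This expectation rests on compound 2, whose limit of > 49000 nM is the only anchor for the new structure. The estimate for compound 3 is 49000 nM with an expected range of 20000 nM to 100000 nM and a high expected chance that only a limit is reported.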

Compound 3, half-maximal effective concentration: > 49000 nM
Compound 3 ended at the assay's limit; the forecaster's own chance of this, stated with the estimate: 80%; the middle value lies on the limit itself.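

In this assay compound 3 gives > 49000 nM, a limit of the assay and not a number. For the compounds shown here, compound 2 also stands at a limit, so no step between compound 2 and compound 3 can be read. The compounds shown leave open whether any change in this series brings a numerical value in this read-out: the limit of > 49000 nM in this assay, at which 3 of the 3 values shown sit.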